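Adding a 4-methylphenyl group to compound 1

A few compounds are considered here, and "the series" means these few. Any claim that something is new, unique, unknown or untested is made for them only; others in the source may bear on it.

Compound 1 `COc1ccc(Nc2ccc3ccccc3n2)cc1` gives 70000 nM
Compound 2 `Fc1ccc(Nc2ccc3ccccc3n2)cc1` gives 65000 nM

For the measured compounds named here, in an ADME assay on PBMC cells (Homo sapiens) for cytotoxicity, read by MTT assay, with a stated time of 72 h, in the presence of a further agent that is not named here (on this read-out higher numbers stand for weaker inhibition and lower numbers for stronger inhibition), compound 1 stands level with compound 2, the only other compound measured so far. Going by the values given here, compound 3 `COc1ccc(Nc2nc3ccccc3cc2-c2ccc(C)cc2)cc1` carries 4-methylphenyl in place of hydrogen on an aromatic carbon of compound 1 4-methylphenyl in place of hydrogen on an aromatic carbon as its one change. Among the compounds with values here, the sole measured step, a 1.1-fold lower number from compound 1 to compound 2 (0.03 log units; within the scatter) for fluoro in place of methoxy, is a different kind of change and offers little guidance. A modest move to a lower number is therefore only a cautious expectation. The expected step is a 2.3-fold lower number from compound 1 to compound 3 (0.37 log units; beyond the scatter) with wide uncertainty. For compound 3 the estimated value is 30000 nM within an expected range of 9000 nM to 90000 nM overall.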

Compound 3, half-maximal inhibitory concentration: 118000 nM
For compound 3 the middle estimate is 3.9-fold (0.59 log units) below the measured one; measured number above the stated range.
By their numbers in this assay, from the lowest: compounds 2, 1 and 3 (each within the scatter of the next).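

In this assay, adding 4-methylphenyl to this aromatic carbon, two atoms from the ring nitrogen, gives a 1.7-fold higher number from compound 1 to compound 3 (0.23 log units; within the scatter). For the compounds shown here, this position therefore carries an added aromatic ring with no change beyond the scatter, a first reading for this site, as the earlier step concerned a different place. No supporting measurement bears on this result. Still open, from the compounds shown here alone, is whether an amine or a carboxylic acid on this same carbon would also stay within the scatter. Also open, going by these compounds, is whether 4-methylphenyl would read the same way on compound 2 .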